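The source may hold more compounds than are shown below. What is called first, only, known or untested is meant among the compounds shown, and "the series" means these compounds.

Working notes, series of hexyloxy benzamides.

Among the compounds with values here, compound 2 `CCCCCCOc1ccc(C(=O)NCCC(C)(C)C)cc1` stands lowest of the two numbers so far in an assay for activation of potassium voltage-gated channel subfamily KQT member 1 (Cavia porcellus) (a lower number here means a stronger inhibitor, a higher number a weaker inhibitor), where compound 2 gives 250 nM. Its nearest neighbour is compound 1 `CCCCCCOc1ccc(C(=O)NCCN(CC)CC)cc1`, which in this assay gives 3500 nM; the step of a 14-fold lower number from compound 1 to compound 2 (1.15 log units; beyond the scatter) is the only measured one and is large. Compound 3 `CCCCCCOc1ccc(C(=O)NCC2CCCC(C)(C)C2)cc1` is not yet measured; it differs from compound 2 by 3,3-dimethylcyclohexyl in place of neopentyl on a saturated chain carbon bound to an amide-type nitrogen. Within the data shown here, no measured step bears directly on this change: the step of a 14-fold lower number from compound 1 to compound 2 (1.15 log units; beyond the scatter) concerns another exchange of groups and gives no direct guide to the saturated ring entering here. The expectation for this assay is therefore a step of no more than modest size, in either direction, most likely within the scatter, written as no change at the digits printed from compound 2 to compound 3 (within the scatter) for the estimate from compound 2 to compound 3. Compound 3 is estimated at 250 nM, with a range from 70 nM to 900 nM.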

Compound 3, half-maximal inhibitory concentration: 370 nM
For compound 3 the middle estimate is 1.5-fold (0.17 log units) below the measured one; the range from low to high includes it.
By their numbers in this assay, from the lowest: compounds 2 and 3 (each within the scatter of the next); then compound 1.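

The step of a 1.5-fold higher number from compound 2 to compound 3 (0.17 log units; within the scatter) shows that in this assay this position takes 3,3-dimethylcyclohexyl, with its six-membered ring of carbon only and 8 heavy atoms against 5 for neopentyl, with no change beyond the scatter. The step of a 9.5-fold lower number from compound 1 to compound 3 (0.98 log units; beyond the scatter) shows that a second all-carbon group, this time a ring, also stands well apart from compound 1, so the gap from compound 1 is not confined to the tert-butyl of compound 2. No measurement at hand explains either step.

Open, from the compounds shown here alone, is whether an unsubstituted cyclohexyl, a cyclopentyl or a phenyl ring would fit the same pattern at this position. Also open, going by these compounds, is how a carboxylic acid or a primary amine would read here, and whether these results hold with a chain shorter than hexyloxy on the shared core.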